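Swapping propyl for prop-1-en-1-yl on a short acid

The compounds below may be only part of what the source reports. "The series", "measured", "known", "first", "only" and "open" are said of these compounds alone.

Compound 1 `CC/C=C(\CCC)C(=O)O` gives 2.59 
Compound 2 `CC/C=C(\CCCC)C(=O)O` gives 3.11 

Going by the values given here, compound 1 holds the lower of the two values measured so far in a physicochemical assay for lipophilicity (a higher number here means a more lipophilic compound, a lower number a more polar compound), and compound 2 lies above it. Among the compounds with values here, the only measured step is a number 0.52 log units higher from compound 1 to compound 2 (beyond the scatter) and it comes with methyl in place of hydrogen on a saturated chain carbon. Compound 3 `C/C=C\C(=C/CC)C(=O)O` has not been measured yet. It differs from compound 1 by prop-1-en-1-yl in place of propyl on a double-bonded chain carbon bound to a carbonyl carbon and a double-bonded chain carbon and this is a different kind of change from the measured one. That step therefore only gives a rough scale, and a small move downward is expected, one the usual scatter could hide. The expected change is a number 0.24 log units lower from compound 1 to compound 3 (within the scatter) in this assay and no firmer claim is possible from two values. Compound 3 is estimated at 2.35 with an expected range of 2.05 to 2.65 on this scale.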

Compound 3, partition coefficient: 2.22
Compound 3: middle estimate off by 0.13 log units, on the high side; the range from low to high includes it.
By their numbers in this assay, from the lowest: compound 3; then compound 1; then compound 2.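

In this assay, prop-1-en-1-yl in place of propyl on a double-bonded chain carbon bound to a carbonyl carbon and a double-bonded chain carbon gives a number 0.37 log units lower from compound 1 to compound 3 (beyond the scatter). This shows that the number at this position can move beyond the scatter even though both groups hold 3 heavy atoms, all carbon, and the entering group differs by 1 double bond outside aromatic rings; the earlier step, made at a different place, went upward. Nothing measured here says why the number moves this way.

The compounds shown leave open how a longer chain, an amine or a phenyl ring would behave at this same position. They also leave open whether this swap would give a similar step on a core other than that of compound 1.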